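The source may report more compounds than this note shows. Statements on the series, on what has been measured and on what is new or still open speak of the compounds shown alone.

Working notes on the series. Compound 1 `COC(=O)N[C@H](C(=O)N1CCC[C@H]1C(=O)Nc1ccc([C@@H]2CC[C@@H](c3ccc(NC(=O)[C@@H]4CCCN4C(=O)[C@@H](NC(=O)OC)[C@@H](C)OC)cc3)N2c2ccc(F)cc2)cc1)[C@@H](C)OC` and compound 2 `COC(=O)N[C@H](C(=O)N1CCC[C@H]1C(=O)Nc1ccc([C@H]2CC[C@H](c3ccc(NC(=O)[C@@H]4CCCN4C(=O)[C@@H](NC(=O)OC)C(C)C)cc3)N2c2ccc(C(F)(F)F)cc2)cc1)C(C)C` have both been run in an ADME assay on the whole organism (plasma) for pharmacokinetics, with Rattus norvegicus as the target, at a dose of 3 mg/kg by the oral route; a lower number here means less compound in the circulation, a higher number more compound in the circulation at the dose given. In this assay compound 1 gives 120 ng.h/mL, and compound 2 gives 1360 ng.h/mL, the higher of the two numbers and a gap well beyond the scatter. Compound 3 `COC(=O)N[C@H](C(=O)N1CCC[C@H]1C(=O)Nc1ccc([C@@H]2CC[C@@H](c3ccc(NC(=O)[C@@H]4CCCN4C(=O)[C@@H](NC(=O)OC)C(C)C)cc3)N2c2ccc(C(F)(F)F)cc2)cc1)C(C)C` differs from compound 2 only in configuration: the two compounds have the same atoms and bonds and differ only in configuration as drawn: 2 of 6 stereo elements differ; a stereocentre at a saturated ring carbon is drawn R in compound 2 and S in compound 3; a stereocentre at a saturated ring carbon is drawn R in compound 2 and S in compound 3. For the measured compounds named here, no measured pair isolates a change of this kind, so the size of the step is uncertain; a drop is expected, as compound 3 shares its ring configuration with compound 1, whose value 120 ng.h/mL is low. The step from compound 2 to compound 3 is estimated at a 3.4-fold lower number from compound 2 to compound 3 (0.53 log units; beyond the scatter), and compound 3 is expected to give about 400 ng.h/mL, with a range from 100 ng.h/mL to 1500 ng.h/mL.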

Compound 3, area under the concentration-time curve: 500 ng.h/mL
The estimate for compound 3 lay 1.3-fold (0.10 log units) below the measured number, and the stated range covers the measured number.
By their numbers in this assay, from the lowest: compound 1; then compound 3; then compound 2.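

Configuration at the two saturated ring carbons now proves to matter on its own in this assay, with a 2.7-fold lower number from compound 2 to compound 3 (0.43 log units; beyond the scatter). The step can be assigned to these two stereocentres because nothing else separates the pair: the fact that compounds 2 and 3 differ only in the configuration as drawn

As far as these compounds go, whether one stereocentre or both together carry the step remains open. So does whether a step of this size would persist with an amine or a longer chain in place of the trifluoromethyl.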